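Swapping a furan for a pyridine on the shared core

A few compounds are considered here, and "the series" means these few. Any claim that something is new, unique, unknown or untested is made for them only; others in the source may bear on it.

Measured so far:
compound 1, `CC(C)c1nn(-c2ccc(C(N)=O)c(N[C@H]3CC[C@H](O)CC3)c2)c2nccc(-n3cnc(-c4ccc(Oc5ccccc5)cc4)c3)c12`, 503 nM;
compound 2, `CC(C)c1nn(-c2ccc(C(N)=O)c(N[C@H]3CC[C@H](O)CC3)c2)c2nccc(-c3ccoc3)c12`, > 10000 nM.

Both compounds were tested in a functional assay on SK-BR-3 cells (Homo sapiens) for inhibition, read by CellTiter-Glo, with a stated time of 72 h; on this read-out higher numbers stand for weaker inhibition and lower numbers for stronger inhibition. Compound 1 gives 503 nM. Compound 2 gives only a limit, > 10000 nM, so no exact number is known for it. On the numbers shown, compound 2 therefore sits at the limit of > 10000 nM in this assay, at which 1 of the 2 values shown sits, the weaker end of what the assay can report, while compound 1 carries a much larger group at the same position of the shared core.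

Compound 3, `CC(C)c1nn(-c2ccc(C(N)=O)c(N[C@H]3CC[C@H](O)CC3)c2)c2nccc(-c3cccnc3)c12`, has not yet been measured. It differs from compound 2 in one place: pyridin-3-yl in place of furan-3-yl on an aromatic carbon. Both groups are small aromatic rings with one hetero atom, so the change is modest compared with the large group of compound 1. A step of this size is expected to move potency little, perhaps bringing the value just into the measurable range; the expected step is an at least 1.2-fold lower number from compound 2 to compound 3 (0.09 log units; that floor lies within the scatter). Compound 3 is estimated to give 8000 nM, with a likely range from 2000 nM to 30000 nM.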

Compound 3, half-maximal inhibitory concentration: 464 nM
For compound 3 the middle estimate is 17-fold (1.24 log units) above the measured one; measured number outside the range, below it.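

Exchanging furan-3-yl for pyridin-3-yl on this aromatic carbon produces an at least 21-fold lower number from compound 2 to compound 3 (1.33 log units; beyond the scatter) in this assay, so this position of the shared core responds strongly to a change between two small aromatic rings. That step is a minimum and not an exact size, because compound 2 gives only a limit and not a number: the limit of > 10000 nM in this assay, at which 1 of the 3 values shown sits.

Compound 1 gives 503 nM and compound 3 gives 464 nM, which shows that a single small ring at this position can reach a number close to that of the much larger group of compound 1.

The change alters two things at once, going from a five-membered to a six-membered ring and from an oxygen to a nitrogen as the hetero atom, and the compounds shown do not separate these two differences. They also leave open how a plain phenyl ring, a pyridin-4-yl ring or a non-aromatic group such as an aminomethyl chain would read at this same place on the shared core.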